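The compounds below may be only part of what the source reports. "The series", "measured", "known", "first", "only" and "open" are said of these compounds alone.

Going by the values given here, in a functional assay on RAW264.7 cells (Mus musculus) for inhibition, with a stated time of 30 min (on this read-out lower numbers stand for stronger inhibition and higher numbers for weaker inhibition), compound 2 `C=C1C(=O)OC[C@@H]1CCOC(=O)Nc1ccc(CCCC)cc1` gives 1230 nM, the highest of the two numbers known so far. Its nearest companion, compound 1 `C=C1C(=O)OC[C@H]1CCOC(=O)Nc1ccc(Cl)cc1`, gives 390 nM in this assay, a gap beyond the usual scatter. The next compound is compound 3 `C=C1C(=O)OC[C@@H]1CCOC(=O)Nc1ccc(Cl)cc1`, which differs from compound 2 by chloro in place of butyl on an aromatic carbon. Since compound 1 also carries a chloro group at that position and gives 390 nM, the change is expected to lower the number, with a step of roughly a 2.5-fold lower number from compound 2 to compound 3 (0.39 log units; beyond the scatter). Compound 3 is therefore estimated at about 500 nM, with a likely range from 150 nM to 2000 nM.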

Compound 3, half-maximal inhibitory concentration: 1070 nM
Compound 3: the middle estimate sits 2.1-fold (0.33 log units) below what was measured; the measured number falls inside the stated range.
By their numbers in this assay, from the lowest: compound 1; then compounds 3 and 2 (each within the scatter of the next).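

Putting chloro in place of butyl on this aromatic carbon gives a 1.1-fold lower number from compound 2 to compound 3 (0.06 log units; within the scatter), so with this configuration the two groups cannot be told apart. Configuration at the saturated ring carbon, by contrast, gives a 2.7-fold higher number from compound 1 to compound 3 (0.44 log units; beyond the scatter). This gap can be assigned to that stereocentre because of one plain fact: the fact that compounds 1 and 3 differ only in the configuration as drawn

On these data alone, whether the same configuration gap appears with butyl in place of chloro remains open. So does whether an amine or a carboxylic acid on this aromatic carbon would shift the number in either configuration.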